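A few compounds are considered here, and "the series" means these few. Any claim that something is new, unique, unknown or untested is made for them only; others in the source may bear on it.

The measurements come from a functional assay on A-375 cells (Homo sapiens), read by thymidine incorporation; on this read-out higher numbers stand for weaker inhibition and lower numbers for stronger inhibition. Compound 1, `CC(=O)N[C@H]1[C@@H](OCc2ccccc2)O[C@H](CO)[C@@H](O)[C@@H]1O`, reaches only a limit: in this assay compound 1 gives > 50 uM. Compound 2, `CC(=O)N[C@H]1[C@@H](OCCCCc2ccccc2)O[C@H](CO)[C@@H](O)[C@@H]1O`, likewise reaches only a limit, as in this assay compound 2 gives > 50 uM. For the measured compounds named here, compound 3, `CCCCCCCCCCCCCCCCO[C@H]1O[C@H](COCC(CO)(CO)COS(=O)(=O)O)[C@@H](O)[C@H](O)[C@H]1NC(=O)CCCC`, is the one compound with an actual number: in this assay compound 3 gives 2.3 uM. That number stands by itself among the three results, since the other two rest at the limit of > 50 uM in this assay, at which 2 of the 3 values shown sit, and cannot be set against it. Compound 4, `CCCCCCCCCCCCCCCCO[C@H]1O[C@H](COCC(CO)(CO)CO)[C@@H](O)[C@H](O)[C@H]1NC(=O)CCCC`, has not yet been measured. It differs from compound 3 in a single place, (hydrogen in place of sulfo on an oxygen on a saturated carbon). Going by the values given here, no measured pair shares this change, so the size of the step is open. The expectation is a modest loss of inhibition, a step of a 2.6-fold higher number from compound 3 to compound 4 (0.42 log units; beyond the scatter), which may or may not exceed the usual scatter. Compound 4 is therefore expected to give about 6 uM in this assay, within a range from 1.5 uM to 25 uM.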

Compound 4, concentration for 50% inhibition: 17 uM
Beside the measured number, compound 4's estimate is 2.8-fold (0.45 log units) below it; low and high end bracket the measured number.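

Replacing the sulfo group with hydrogen, which turns the (sulfooxy)methyl group into hydroxymethyl, gives a 7.4-fold higher number from compound 3 to compound 4 (0.87 log units; beyond the scatter) in this assay, so inhibition weakens. For the compounds shown here, this is the first measured step at this place, and it shows that the sulfo group counts for the result without being indispensable: without it, compound 4 still gives a real number, 17 uM, and not a limit. Nothing shown accounts for the size of this step.

The compounds shown leave open whether a carboxylic acid or a phosphate in place of the sulfo group would keep the inhibition of compound 3. They also leave open how a shorter chain in place of the long chain that compound 3 and compound 4 share would affect either compound.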